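Swapping Cyano for Chloro: an Expectation for Compound 4

The source may hold more compounds than are shown below. What is called first, only, known or untested is meant among the compounds shown, and "the series" means these compounds.

Measured in an assay on CHO cells for displacement of a labelled ligand from prostaglandin D2 receptor 2 (Homo sapiens), read by scintillation counting; a lower number here means a stronger inhibitor, a higher number a weaker inhibitor:
Compound 1, `CC(C)c1ccc(S(C)(=O)=O)cc1C#Cc1cc(C#N)ccc1OCC(=O)O`, gives 12 nM.
Compound 2, `Cc1ccc(S(=O)(=O)N2CCN(C)CC2)cc1C#Cc1cc(Cl)ccc1OCC(=O)O`, gives 21 nM.
Compound 3, `CCCS(=O)(=O)c1ccc(C)c(C#Cc2cc(Cl)ccc2OC(C)C(=O)O)c1`, gives 1.2 nM.

Among these three numbers compound 1 stands second highest. Compound 2 lies within the usual scatter of compound 1, so the two cannot be told apart. Compound 3 lies beyond the scatter on the low side, which makes compound 3 a clearly stronger inhibitor than compound 1.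

Compound 4, `CC(C)c1ccc(S(C)(=O)=O)cc1C#Cc1cc(Cl)ccc1OCC(=O)O`, has not yet been measured. It differs from compound 1 in one place: chloro in place of cyano on an aromatic carbon. Going by the values given here, no two measured compounds differ from each other only in this way, so there is no directly comparable step to lean on. Compounds 2 and 3 both carry chloro at this position, yet their numbers fall on either side of compound 1, and each differs from compound 1 in further places too.

The expectation is therefore a step of no size beyond the scatter in this assay, in either direction, from compound 1 to compound 4 a 1.2-fold lower number from compound 1 to compound 4 (0.08 log units; within the scatter). Compound 4 is estimated at 10 nM, with a range from 3 nM to 30 nM.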

Compound 4, inhibition constant: 4.6 nM
The estimate for compound 4 lay 2.2-fold (0.34 log units) above the measured number; the measured number falls inside the stated range.
By their numbers in this assay, from the lowest: compound 3; then compound 4; then compounds 1 and 2 (each within the scatter of the next).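

Putting chloro in place of cyano on this aromatic carbon, para to a carboxymethoxy group, gives a 2.6-fold lower number from compound 1 to compound 4 (0.42 log units; beyond the scatter) in this assay. Going by these compounds alone, compounds 1 and 4 are the only pair here that differ in one place, so this is the first direct sign that the group at this position affects the number, even if the step is modest. No measurement shown here accounts for the step.

As far as these compounds go, only cyano and chloro appear at this position, so it remains open whether a fluoro, a methoxy or an amine group here would give a lower or a higher number. From the compounds shown here alone, it is also open whether chloro would keep its edge over cyano on the differing structures of compounds 2 and 3, neither of which has a cyano partner.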